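The source may hold more compounds than are shown below. What is called first, only, known or untested is meant among the compounds shown, and "the series" means these compounds.

Compound 2, `O=C(O)/C(S)=C/c1c[nH]c2ccc(Br)cc12`, is the strongest inhibitor of the set: in an assay on isolated protein for inhibition of Calpain-1 catalytic subunit (Sus scrofa), read by FRET (a lower number here means a stronger inhibitor, a higher number a weaker inhibitor), compound 2 gives 6 nM. Compound 1, `O=C(O)/C(S)=C/c1c[nH]c2ccc(I)cc12`, carries iodo in place of bromo on an aromatic carbon; in this assay compound 1 gives 100 nM, so the step of a 17-fold higher number from compound 2 to compound 1 (1.22 log units; beyond the scatter) leaves a markedly weaker inhibitor. Compound 3, `O=C(O)/C(S)=C/c1ccccc1Br`, rests on a different core, and the difference between the two cores is not broken down here. In this assay compound 3 gives 21000 nM, the highest number of the three. Compound 4, `O=C(O)/C(S)=C/c1ccccc1I`, has not yet been measured. It differs from compound 3 by iodo in place of bromo on an aromatic carbon. This is the same kind of change as from compound 2 to compound 1, though the surroundings differ: there the halogen sat on a ring that is part of a fused or bridged system of two rings, meta to a fused ring and para to a fused ring, while here it sits on a six-membered aromatic ring of carbon only, ortho to a group of 6 heavy atoms. Compound 4 is expected to inhibit less strongly than compound 3, because a 17-fold higher number from compound 2 to compound 1 (1.22 log units; beyond the scatter) went the same way in a single earlier example, but the changed surroundings make the size uncertain. The expected step is a 2.4-fold higher number from compound 3 to compound 4 (0.38 log units; beyond the scatter). Compound 4 is estimated at 50000 nM, likely between 12000 nM and 250000 nM.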

Compound 4, half-maximal inhibitory concentration: 29600 nM
For compound 4 the middle estimate is 1.7-fold (0.23 log units) above the measured one; the range from low to high includes it.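

In this assay, putting iodo in place of bromo on the six-membered aromatic ring of carbon only gives a 1.4-fold higher number from compound 3 to compound 4 (0.15 log units; within the scatter), so on this core the swap makes no clear difference to inhibition. The same change therefore does not carry its size from one core to the other: the same change on two cores in this assay, a 17-fold higher number (1.22 log units; beyond the scatter) from compound 2 to compound 1 and a 1.4-fold higher number (0.15 log units; within the scatter) from compound 3 to compound 4, 12-fold (1.07 log units) apart, beyond the scatter of two such steps These two pairs show that the effect of this swap depends on the core around it, but they do not show which part of the two cores accounts for the gap, and two pairs cannot establish a rule for the whole series.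

The compounds shown carry only bromo and iodo, so it remains open how a smaller group such as chloro, fluoro or methyl would behave in the same place on either core. Also open, from the compounds shown here alone, is whether an amide in place of the carboxylic acid would change the picture.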